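Swapping an oxadiazole for a thiophene: rat clearance outlook

A few compounds are considered here, and "the series" means these few. Any claim that something is new, unique, unknown or untested is made for them only; others in the source may bear on it.

Compound 1 `CCC(CC)C1C(C(=O)c2ccc(OC)cc2)=C(O)C(=O)N1c1ccc(-c2ccon2)cc1` gives 5.1 mL/min/kg in an ADME assay on the whole organism (Rattus norvegicus) for pharmacokinetics; on this read-out lower numbers stand for slow clearance and higher numbers for fast clearance.
Compound 2 `Cc1cc(-c2ccc(N3C(=O)C(O)=C(C(=O)C(C)(C)C)C3c3ccccc3OCCO)cc2)on1` gives "not determined" (no result reported) in this assay.
Compound 3 `Cc1noc(-c2ccc(N3C(=O)C(O)=C(C(=O)C(C)(C)C)C3c3ccccc3OCCO)cc2)n1` gives "not determined" (no result reported) in this assay.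

Only compound 1 carries a number, and that number points to slow clearance. Compound 3 stands without any value of its own, and compound 2, which shares its core and differs only in the five-membered aromatic ring on the outer phenyl, is likewise without a result. So there is no measured step that leads to compound 3, and nothing yet tells how its core behaves in this assay.

Compound 4 `CC(C)(C)C(=O)C1=C(O)C(=O)N(c2ccc(-c3cccs3)cc2)C1c1ccccc1OCCO` is the next step from compound 3. The change is thiophen-2-yl in place of 3-methyl-1,2,4-oxadiazol-5-yl on an aromatic carbon, in words: thiophen-2-yl in place of 3-methyl-1,2,4-oxadiazol-5-yl on an aromatic carbon. Among the compounds with values here, no measured pair shows what such a change does here, and compound 3 has no number to step from. Within the data shown here, the only anchor is compound 1, whose slow clearance comes from a related but not identical core. Among the measured compounds shown here, with that single anchor, compound 4 is expected to fall near the slow end, estimated at 8 mL/min/kg with a wide range from 3 mL/min/kg to 25 mL/min/kg, and no direction of step from compound 3 can be claimed.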

Compound 4, clearance: 1.3 mL/min/kg
Compound 4: middle estimate off by 6.2-fold (0.79 log units), on the high side; the whole stated range lies above it.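

In this assay, within the data shown here, compound 3 has no single number, so no step from it to compound 4 can be read. Nothing available explains the value of compound 4. From the compounds shown here alone, what replacing 3-methyl-1,2,4-oxadiazol-5-yl with thiophen-2-yl does to clearance on this shared core therefore remains open.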